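Notes on the step from compound 1 to compound 4

The compounds below may be only part of what the source reports. "The series", "measured", "known", "first", "only" and "open" are said of these compounds alone.

Values so far in a toxicity assay on MCF-10A cells (Homo sapiens) for inhibition, read by MTT assay, with a stated time of 72 h; on this read-out lower numbers stand for stronger inhibition of growth and higher numbers for weaker inhibition of growth:
Compound 1, `O=S(=O)(NCCCNCc1ccccc1Cl)c1cc(C(F)(F)F)cc(C(F)(F)F)c1`: 11000 nM
Compound 2, `O=S(=O)(NCCCNCc1ccc(Cl)c(Cl)c1)c1cc(C(F)(F)F)cc(C(F)(F)F)c1`: 3000 nM
Compound 3, `O=S(=O)(NCCCNCc1ccc(Cl)c(C(F)(F)F)c1)c1cc(C(F)(F)F)cc(C(F)(F)F)c1`: 7900 nM

Compound 1 gives the highest of the three numbers; compound 3 sits within the scatter of it, compound 2 lies beyond it with a 3.7-fold lower number from compound 1 to compound 2 (0.56 log units; beyond the scatter). Compound 4, `O=S(=O)(NCCCNCc1ccc(Cl)cc1)c1cc(C(F)(F)F)cc(C(F)(F)F)c1`, is not yet measured. It differs from compound 1 as follows: 4-chlorophenyl in place of 2-chlorophenyl on a saturated chain carbon bound to an amine nitrogen.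

Two measured steps start from the same 2-chlorophenyl group of compound 1 and therefore bear on this change. Exchanging it for 3,4-dichlorophenyl gave a 3.7-fold lower number from compound 1 to compound 2 (0.56 log units; beyond the scatter), a modest shift; exchanging it for 4-chloro-3-(trifluoromethyl)phenyl gave a 1.4-fold lower number from compound 1 to compound 3 (0.14 log units; within the scatter), no more than scatter. Both replacements keep a chlorine on the ring and both moved the number downward or left it unchanged. The shift to plain 4-chlorophenyl is expected to behave like the smaller of these, so compound 4 is estimated at 6500 nM, within 2700 nM to 16000 nM. That corresponds to an expected step of a 1.7-fold lower number from compound 1 to compound 4 (0.23 log units; within the scatter), which may well fall inside the scatter.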

Compound 4, concentration for 50% growth inhibition: 2300 nM
Estimate against measurement, compound 4: 2.8-fold (0.45 log units) above, outside the stated range (below it).
By their numbers in this assay, from the lowest: compounds 4 and 2 (each within the scatter of the next); then compounds 3 and 1 (each within the scatter of the next).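

In this assay, the same atoms joined differently, as 4-chlorophenyl in place of 2-chlorophenyl, give a 4.8-fold lower number from compound 1 to compound 4 (0.68 log units; beyond the scatter), so the location of the single chlorine on this ring alone carries a step beyond the scatter. A further ring substituent adds nothing measurable in one case, since hydrogen in place of chloro gives a 1.3-fold lower number from compound 2 to compound 4 (0.12 log units; within the scatter), which is within the scatter. Trifluoromethyl is not equivalent, since hydrogen in its place gives a 3.4-fold lower number from compound 3 to compound 4 (0.54 log units; beyond the scatter), so among these compounds the lower numbers go with 4-chlorophenyl and 3,4-dichlorophenyl.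

Nothing available explains why the location of the chlorine matters here. Also open, as far as these compounds go, is whether a phenyl group carrying no chlorine, or one carrying bromine instead, would group with compound 4 or with compound 1.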